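The compounds below may be only part of what the source reports. "The series", "measured", "known", "first", "only" and "open" are said of these compounds alone.

In a functional assay on A549 cells (Homo sapiens) for cytotoxicity, read by MTT assay (a lower number here means a stronger inhibitor, a higher number a weaker inhibitor), compound 1 `COc1ccc(OC)c(C(=O)/C=C/c2cccs2)c1` gives 11000 nM and compound 2 `COc1ccc(OC)c(C(=O)/C=C/c2ccc(C)o2)c1` gives 51500 nM, the higher of the two numbers. Compound 3 `COc1ccc(OC)c(C(=O)/C=C/c2ccc(C)s2)c1` carries 5-methylthiophen-2-yl in place of 5-methylfuran-2-yl on a double-bonded chain carbon bound to a double-bonded chain carbon. Within the data shown here, the one measured step bearing on this, a 4.7-fold higher number from compound 1 to compound 2 (0.67 log units; beyond the scatter), is modest and runs from thiophen-2-yl to 5-methylfuran-2-yl, so it also includes the methyl. A somewhat smaller step in the reverse direction is therefore expected in this assay. For compound 3 the estimate is 17000 nM, within a range of 7000 nM to 40000 nM. The estimated change is a 3.0-fold lower number from compound 2 to compound 3 (0.48 log units; beyond the scatter).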

Compound 3, half-maximal inhibitory concentration: 4500 nM
Beside the measured number, compound 3's estimate is 3.8-fold (0.58 log units) above it; measured number outside the range, below it.
By their numbers in this assay, from the lowest: compound 3; then compound 1; then compound 2.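

With the methyl kept, 5-methylthiophen-2-yl in place of 5-methylfuran-2-yl gives an 11-fold lower number from compound 2 to compound 3 (1.06 log units; beyond the scatter) in this assay and isolates the ring exchange, which the earlier step mixed with the methyl. Methyl in place of hydrogen on the thiophene gives a 2.4-fold lower number from compound 1 to compound 3 (0.39 log units; beyond the scatter) as a separate, smaller step, so on this ring the methyl goes with a lower number, not a higher one. Nothing on hand explains either step. Still open, as far as these compounds go, is how furan-2-yl without the methyl would read, and so whether the methyl step holds on the furan. Also open, from the compounds shown here alone, is how ethyl or aminomethyl in place of the methyl would read.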